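Propargylamine aminoindane series: amide tail change on compound 2

The source may hold more compounds than are shown below. What is called first, only, known or untested is meant among the compounds shown, and "the series" means these compounds.

Measured compounds:
compound 1, `C#CCNC1CCc2c(NCc3cccc(C)c3)cccc21` — 710 nM
compound 2, `C#CCNC1CCc2c(OCCc3cc(NC(=O)c4ccc(F)cc4)ccc3Cl)cccc21` — 5100 nM

In an assay on cells for inhibition of Amine oxidase [flavin-containing] B (Homo sapiens), read by fluorescence and Amplex Red, with stated times of 30 min and 15 min (on this read-out lower numbers stand for stronger inhibition and higher numbers for weaker inhibition), compound 2 gives 5100 nM, the highest of the two numbers shown. Its nearest neighbour is compound 1, which in this assay gives 710 nM; the two structures differ in more than one place, so the gap between them reads only as a difference between two values, not as a single step.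

Compound 3, `C#CCNC1CCc2c(OCCc3cc(NC(=O)COC(C)=O)ccc3Cl)cccc21`, has not yet been measured in this assay. It differs from compound 2 by acetoxymethyl in place of 4-fluorophenyl on a carbonyl carbon, an acetoxymethyl in place of 4-fluorophenyl on a carbonyl carbon. Within the data shown here, no measured pair shows this exchange. Compound 3 is expected to come out weaker than or close to compound 2, with the step of a 1.6-fold higher number from compound 2 to compound 3 (0.20 log units; within the scatter) estimated as modest and possibly within the scatter. For compound 3 the expected value is 8000 nM, with a range from 2500 nM to 25000 nM.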

Compound 3, half-maximal inhibitory concentration: 480 nM
Estimate against measurement, compound 3: 17-fold (1.22 log units) above, outside the stated range (below it).
By their numbers in this assay, from the lowest: compounds 3 and 1 (each within the scatter of the next); then compound 2.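

In this assay, the group on the carbonyl carbon of the amide matters to the read-out: acetoxymethyl in place of 4-fluorophenyl gives an 11-fold lower number from compound 2 to compound 3 (1.03 log units; beyond the scatter) in a single exchange, whereas compound 1 and compound 2 differ in more than one place and could not isolate any one change. An aromatic ring on this carbonyl is therefore not needed for the activity of compound 3, since the acetoxymethyl that enters has no ring. Nothing at hand explains the size of this step.

On these data alone, it remains open whether the step comes from the loss of the 4-fluorophenyl or from the acetoxymethyl itself, which a methyl, a hydroxymethyl or an unsubstituted phenyl on the same carbonyl would help separate. Also open, as far as these compounds go, is how a longer chain ending in an amine or a carboxylic acid would read at this position.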